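Methoxy to ethoxy on the oxime of compound 3

The source may hold more compounds than are shown below. What is called first, only, known or untested is meant among the compounds shown, and "the series" means these compounds.

Compound 3 `CON=C1CCC(CN2C(C)CN(c3nc(=O)c4cc(C(F)(F)F)cc([N+](=O)[O-])c4s3)CC2C)CC1` was examined in an ADME assay on Vero cells (Chlorocebus sabaeus) for cytotoxicity; on this read-out lower numbers stand for higher toxicity in this test and higher numbers for lower toxicity in this test. In this assay compound 3 gives > 64 ug/mL, which is a limit of the assay and not a number. The unmeasured compound 4 `CCON=C1CCC(CN2C(C)CN(c3nc(=O)c4cc(C(F)(F)F)cc([N+](=O)[O-])c4s3)CC2C)CC1` differs from it by methyl in place of hydrogen on a saturated chain carbon bound to an oxygen on an unsaturated carbon. Compound 1 `CCO/N=C(\C)CN1CCN(c2nc(=O)c3cc(C(F)(F)F)cc([N+](=O)[O-])c3s2)CC1` and compound 2 `CON=C1CCC(CN2CCN(c3nc(=O)c4cc(C(F)(F)F)cc([N+](=O)[O-])c4s3)CC2)CC1` share the same core. In this assay compound 1 gives > 64 ug/mL, a limit. In this assay compound 2 gives > 64 ug/mL, also a limit. Among the measured compounds shown here, the only computed step, a step that the two limits leave unreadable from compound 1 to compound 2, thus gives no size. For the measured compounds named here, no measured step touches the change from methoxy to ethoxy, and the limit of > 64 ug/mL in this assay, at which 3 of the 3 values shown sit, shows every value resting at that limit. Compound 4 is expected to show a number no higher from compound 3 to compound 4 (the limit leaves the size open), no step beyond the scatter. For compound 4 the estimated value is 64 ug/mL, with a range from 32 ug/mL to 128 ug/mL.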

Compound 4, half-maximal cytotoxic concentration: 60.5 ug/mL
For compound 4 the middle estimate is 1.1-fold (0.02 log units) above the measured one, within the range that was stated.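

The change from methoxy to ethoxy gives an at least 1.0-fold lower number from compound 3 to compound 4 (0.02 log units; that floor lies within the scatter) in this assay. Compound 4 is the first compound shown with a number and not a limit, so this position can now yield a readable value, although the step shows no change beyond the scatter. The true size of the step stays open because compound 3 rests at a limit: the limit of > 64 ug/mL in this assay, at which 3 of the 4 values shown sit.

Going by these compounds, whether a longer chain such as propyl, or a benzyl group, in place of ethyl would move the number beyond the scatter remains open. So does whether ethoxy would act the same way in compound 2.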